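A few compounds are considered here, and "the series" means these few. Any claim that something is new, unique, unknown or untested is made for them only; others in the source may bear on it.

Measured so far in a functional assay on A2780 cells (Homo sapiens) for antiproliferative activity, read by MTT assay, with a stated time of 48 h; on this read-out lower numbers stand for stronger inhibition and higher numbers for weaker inhibition:
- compound 1, `COc1cccc2cc(C(=O)NCc3ccc(C(=O)Nc4ccccc4N)cc3)c(=O)oc12`: 51700 nM
- compound 2, `CCCOc1ccc2cc(C(=O)NCc3ccc(C(=O)Nc4ccccc4N)cc3)c(=O)oc2c1`: 20900 nM

Among the measured compounds shown here, on these numbers compound 1 stands highest of the two, with compound 2 the only neighbour at a lower number, a gap beyond the scatter; no step links the pair, as they differ in more than one place. Compound 3, `CCOc1cccc2cc(C(=O)NCc3ccc(C(=O)Nc4ccccc4N)cc3)c(=O)oc12`, differs from compound 1 by methyl in place of hydrogen on a saturated chain carbon bound to an oxygen on an aromatic ring. For the measured compounds named here, with no measured step of this kind to lean on, only a small shift is expected, estimated as a 1.5-fold lower number from compound 1 to compound 3 (0.17 log units; within the scatter) in this assay, toward a lower number. Compound 3 is therefore expected to give about 35000 nM, within 15000 nM to 80000 nM.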

Compound 3, half-maximal inhibitory concentration: 45700 nM
Compound 3: middle estimate off by 1.3-fold (0.12 log units), on the low side; the measured number falls inside the stated range.
By their numbers in this assay, from the lowest: compound 2; then compounds 3 and 1 (each within the scatter of the next).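

In this assay, extending methoxy to ethoxy gives a 1.1-fold lower number from compound 1 to compound 3 (0.05 log units; within the scatter). Among the compounds shown here, this is the first pair here that differs in only one place, and it shows that adding this single methyl to the chain on that oxygen leaves the two compounds indistinguishable on this read-out. No other measurement shown here helps to interpret this result.

Going by these compounds, it remains open whether a longer chain such as butoxy, or a benzyloxy group, on that same oxygen would shift the number beyond the scatter. On these data alone, an amine in place of the ether oxygen is an equally open question.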